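The source may hold more compounds than are shown below. What is called first, only, known or untested is meant among the compounds shown, and "the series" means these compounds.

Three close relatives of a shared core have been tested in an assay on membranes from CHO cells for displacement of a labelled ligand from adenosine receptor A1 (Homo sapiens), read by scintillation counting, with a stated time of 60 min, tested at 1 uM; on this read-out higher numbers stand for more inhibition at the one concentration tested (going by the name of the read-out) and lower numbers for less inhibition. Compound 1 `CC1=C(C(=O)OC(C)(C)C)C(c2ccoc2)NC(=O)N1` gives 11%, compound 2 `CC1=C(C(=O)OC(C)(C)C)C(c2ccsc2)NC(=O)N1` gives 15%, and compound 3 `CC1=C(C(=O)OC(C)(C)C)C(c2ccsc2)NC(=O)N1C` gives 18%. Compound 2 stands between the other two, since the step of a number 4 percentage points higher from compound 1 to compound 2 (within the scatter) and the step of a number 3 percentage points higher from compound 2 to compound 3 (within the scatter) both stay within the usual scatter. Compound 4 `CC1=C(C(=O)OCC2CCC2)C(c2ccsc2)NC(=O)N1` differs from compound 2 by cyclobutylmethyl in place of tert-butyl on an oxygen next to a carbonyl group. Neither measured step touches this part of the molecule, so nothing here shows what this change does; the two measured steps only show that small changes elsewhere left this assay nearly unmoved. The expected step of no change at the digits printed from compound 2 to compound 4 (within the scatter) is therefore none beyond the scatter. Compound 4 is estimated to give 15%, within 3% to 30%.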

Compound 4, a percentage reported as inhibition, at one concentration (the size of the read-out at that concentration, not a potency): 48%
The estimate for compound 4 lay 33 percentage points below the measured number; measured number above the stated range.
By their numbers in this assay, from the lowest: compounds 1, 2 and 3 (each within the scatter of the next); then compound 4.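

In this assay, cyclobutylmethyl in place of tert-butyl on an oxygen next to a carbonyl group gives a number 33 percentage points higher from compound 2 to compound 4 (beyond the scatter). Among these compounds, the two earlier steps stayed within the scatter, so this is the first sign that the read-out responds to a change in the shared core, and here the group on this oxygen is what differs. Nothing available here gives a reason for this rise. From the compounds shown here alone, whether the four-membered ring itself matters stays open. An open chain such as n-pentyl, or a chain ending in an amine, on this oxygen could read quite differently.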